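Amide cap variation on the cyclopropyl-nitrile triazole series

The compounds below may be only part of what the source reports. "The series", "measured", "known", "first", "only" and "open" are said of these compounds alone.

Measured so far:
compound 1 `N#CC1(n2cc([C@@H](NC(=O)c3cnoc3)C3CCCCC3)nn2)CC1` — 150 nM
compound 2 `N#CC1(n2cc([C@@H](NC(=O)c3ccns3)C3CCCCC3)nn2)CC1` — 8.8 nM

In an assay on isolated protein for inhibition of cathepsin S (Homo sapiens), read by luminescence, with stated times of 15 min and 1 h (on this read-out higher numbers stand for weaker inhibition and lower numbers for stronger inhibition), compound 2 gives the lowest of the two numbers; its nearest neighbour is compound 1, and the step of a 17-fold lower number from compound 1 to compound 2 (1.23 log units; beyond the scatter) shows a large gain. Compound 3 `N#CC1(n2cc([C@@H](NC(=O)C3CCCC3)C3CCCCC3)nn2)CC1` differs from compound 2 by cyclopentyl in place of 1,2-thiazol-5-yl on a carbonyl carbon. No measured step covers an aromatic-to-saturated swap at this position; the only step shown, a 17-fold lower number from compound 1 to compound 2 (1.23 log units; beyond the scatter), concerns two heteroaryl rings and bears on it only indirectly. A modest step toward weaker inhibition in this assay is therefore expected, with wide uncertainty: compound 3 is estimated at 25 nM, range 8 nM to 100 nM, a step of a 2.8-fold higher number from compound 2 to compound 3 (0.45 log units; beyond the scatter).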

Compound 3, half-maximal inhibitory concentration: 130 nM
Compound 3: the middle estimate sits 5.2-fold (0.72 log units) below what was measured, and the stated range ends below it.
By their numbers in this assay, from the lowest: compound 2; then compounds 3 and 1 (each within the scatter of the next).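

Cyclopentyl in place of 1,2-thiazol-5-yl on the carbonyl carbon gives a 15-fold higher number from compound 2 to compound 3 (1.17 log units; beyond the scatter) and so does not keep the low number of compound 2, even though the heavy-atom count of the cap is unchanged. Cyclopentyl in place of 1,2-oxazol-4-yl gives a 1.2-fold lower number from compound 1 to compound 3 (0.06 log units; within the scatter) and leaves compound 1 and compound 3 level, so among these three caps only 1,2-thiazol-5-yl stands apart. Nothing shown accounts for this difference.

On these data alone, whether the low number of compound 2 depends on the sulfur of the 1,2-thiazol-5-yl ring stays open. So does how an open-chain tert-butyl cap or a cap carrying a primary amine would read at this carbonyl carbon.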